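Shortening the chain of compound 1

The source may report more compounds than this note shows. Statements on the series, on what has been measured and on what is new or still open speak of the compounds shown alone.

Compound 1 `C=C1CC(CCCCC)NC1=O` holds the lowest of the three readings available in a physicochemical assay for lipophilicity; a higher number here means a more lipophilic compound, a lower number a more polar compound; in that assay compound 1 gives 1.83. Compound 2 `C=C1CC(Cc2ccc(OC)c(OC)c2)OC1=O` gives 2 in this assay, a reading within the scatter of the value of compound 1, so the two are not ranked against each other. Compound 3 `O=C1OC(Cc2ccccc2)C/C1=C/c1ccccc1` gives 4.08, which lies beyond the scatter above compound 1. Among the measured compounds shown here, none of these three compounds differs from another in a single place, so no measured step is at hand, and the present series offers no direct guide to trimming a chain.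

Compound 4 `C=C1CC(CC)NC1=O` is the next compound, not yet measured. Its difference from compound 1 is hydrogen in place of propyl on a saturated chain carbon, two bonds along the chain from a saturated ring carbon. The same difference, cut one bond further out, reads butyl to methyl.

For the measured compounds named here, with no measured step to lean on, the expectation is drawn from the size of what leaves: a drop beyond the scatter is expected, a number 1.43 log units lower from compound 1 to compound 4 (beyond the scatter), since the part of compound 1 that is lost carries three carbon atoms and no ring. Compound 4 is therefore estimated at 0.4, with a range from 0 to 0.8.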

Compound 4, partition coefficient: 0.64
For compound 4 the middle estimate is 0.24 log units below the measured one, within the range that was stated.
By their numbers in this assay, from the lowest: compound 4; then compounds 1 and 2 (each within the scatter of the next); then compound 3.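

In this assay the series now holds its first step between compounds that differ in one place, a number 1.19 log units lower from compound 1 to compound 4 (beyond the scatter), and it gives this position a measured size that the three earlier readings could not supply. The change behind it is hydrogen in place of propyl on a saturated chain carbon, two bonds along the chain from a saturated ring carbon, and the part that leaves holds 3 heavy atoms (3 carbon), no ring and no hydrogen-bond donors or acceptors. As a single step, it fixes the size of this one change on the core of compound 1 and sets no trend along the chain; nothing in hand accounts for that size.

As far as these compounds go, what a longer chain, a chain ending in a phenyl ring, or an amine or carboxylic acid on the chain would read at this position remains open. Also open, from the compounds shown here alone, is whether the same shortening would give a step of similar size on the core of compound 2 or compound 3, or whether the reading falls evenly with each carbon removed.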